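Swapping the amide-side ring: pyridine to pyrimidine

The source may report more compounds than this note shows. Statements on the series, on what has been measured and on what is new or still open speak of the compounds shown alone.

In a functional assay on cells for antagonist activity at D(4) dopamine receptor (Homo sapiens), read by TR-FRET and cAMP accumulation, with a stated time of 30 min (on this read-out lower numbers stand for stronger inhibition and higher numbers for weaker inhibition), three compounds have been measured. Compound 1 `O=C(CN1CCN(c2ccccn2)CC1)Nc1cccnc1` gives 86500 nM. Compound 3 `O=C(CN1CCN(c2ccc(Cl)cn2)CC1)Nc1cccnc1` gives 40000 nM, which places it second highest of the three numbers, with compound 1 giving the nearest number. Compound 2 `Cc1cccc(NC(=O)CN2CCN(c3cccc4ccccc34)CC2)c1` gives 2520 nM, the lowest number of the three; it differs from compound 3 in more than one place, so only the two values themselves can be compared. For the measured compounds named here, the one single-site step recorded so far is a 2.2-fold lower number from compound 1 to compound 3 (0.33 log units; beyond the scatter).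

Compound 4 `O=C(CN1CCN(c2ccc(Cl)cn2)CC1)Nc1cncnc1` is compound 3 with one change: pyrimidin-5-yl in place of pyridin-3-yl on an amide-type nitrogen. Going by the values given here, no measured step touches this amide-side ring; the chloro step from compound 1 to compound 3 sits on the other end of the molecule and gives no guide for this change. Among the compounds with values here, with no bearing precedent, the expectation in this assay is a step of about a 1.3-fold higher number from compound 3 to compound 4 (0.10 log units; within the scatter), essentially none beyond the scatter. Compound 4 is therefore estimated at 50000 nM, with a range from 15000 nM to 150000 nM.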

Compound 4, half-maximal inhibitory concentration: > 100000 nM
Compound 4: only a limit was reported; the forecaster's own chance of this, stated with the estimate: 20%; middle value at least 2.0-fold (0.30 log units) away from the limit.
By their numbers in this assay, from the lowest: compound 2; then compound 3; then compound 1. At a limit, above all of these: compound 4.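

For the compounds shown here, this is the first measured change on the amide-side ring, and it shows that this position is not indifferent in this assay: pyrimidin-5-yl in place of pyridin-3-yl on an amide-type nitrogen gives an at least 2.5-fold higher number from compound 3 to compound 4 (0.39 log units; beyond the scatter). On this read-out a higher number stands for weaker inhibition, so this swap moves the compound in the unfavourable direction, whereas the chloro change at the other end of the molecule gave a lower number. For compound 4 the reported figure is a limit and not a number: the limit of > 100000 nM in this assay, at which 1 of the 4 values shown sits.

As far as these compounds go, the true size of the step therefore stays open, and only its direction and minimum can be read. Also open, from the compounds shown here alone, is how this amide-type nitrogen would respond to an unsubstituted phenyl ring, or to a pyridin-3-yl ring carrying a fluorine or a methoxy group.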